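Trading the acid chain for a methoxy group

This account rests on a few compounds, and the source may have more. Where it says the series, first, only, none or still open, it means among the compounds named here.

Measured so far in an ADME assay on MT4 cells (Homo sapiens) for cytotoxicity, read by MTT assay, with a stated time of 96 h; on this read-out lower numbers stand for higher toxicity in this test and higher numbers for lower toxicity in this test:
compound 1 `Fc1ccc(-c2nc3cc(C(F)(F)F)ccc3[nH]2)cc1`: 22000 nM
compound 2 `O=C(CN1CCCC1)Nc1ccc(-c2nc3cc(C(F)(F)F)ccc3[nH]2)cc1`: 18000 nM
compound 3 `O=C(O)CCC(=O)Nc1ccc(-c2nc3cc(C(F)(F)F)ccc3[nH]2)cc1`: > 100000 nM

Of these three, compound 3 stands apart. Its result in this assay is not a number but a limit of the assay, as noted by the limit of > 100000 nM in this assay, at which 1 of the 3 values shown sits, so it is known only to sit beyond the other two. The path to compound 3 shows this clearly: an at least 4.5-fold higher number from compound 1 to compound 3 (0.65 log units; beyond the scatter), and an at least 5.5-fold higher number from compound 2 to compound 3 (0.74 log units; beyond the scatter).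

The next compound, compound 4 `COc1ccc(-c2nc3cc(C(F)(F)F)ccc3[nH]2)cc1`, undoes that change. The difference is methoxy in place of ((2-carboxyethyl)carbonyl)amino on an aromatic carbon. The step into compound 3 was what carried the number out of the measurable range. The step out of it is expected to move the number back toward the range of compound 1, which gave 22000 nM, and compound 2, which gave 18000 nM. The expected step is therefore an at least 4.0-fold lower number from compound 3 to compound 4 (0.60 log units; beyond the scatter). For compound 4 the estimate in this assay is 25000 nM, with a likely range from 10000 nM to 80000 nM.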

Compound 4, half-maximal cytotoxic concentration: 2000 nM
Compound 4: middle estimate off by 13-fold (1.10 log units), on the high side, outside the stated range (below it).
By their numbers in this assay, from the lowest: compound 4; then compounds 2 and 1 (each within the scatter of the next). At a limit, above all of these: compound 3.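

In this assay, this aromatic carbon, para to a large group, can also carry a group that pushes the number down, and compound 4 has the lowest number of the set, with an 11-fold lower number from compound 1 to compound 4 (1.04 log units; beyond the scatter) and a 9.0-fold lower number from compound 2 to compound 4 (0.95 log units; beyond the scatter). Among the earlier compounds, the only steps beyond the scatter went upward, so a clear fall at this position is new. The widest gap is an at least 50-fold lower number from compound 3 to compound 4 (1.69 log units; beyond the scatter), and its size is only a minimum since the value of compound 3 is a limit of the assay: the limit of > 100000 nM in this assay, at which 1 of the 4 values shown sits.

The compounds shown leave open whether the low number belongs to methoxy alone or would also appear with a hydroxy or an ethoxy group on this carbon. They also cannot show why methoxy differs from fluoro here, as no measured property accompanies this result.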